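This account rests on a few compounds, and the source may have more. Where it says the series, first, only, none or still open, it means among the compounds named here.

Compound 1, with the structure `Cc1[nH]n(-c2nc3cc(-c4ccccc4)ccc3[nH]2)c(=O)c1Cc1ccccc1`, is the starting point. In an assay on isolated protein for inhibition of alpha-ketoglutarate-dependent dioxygenase alkB homolog 3 (Homo sapiens), read by polymerase chain reaction, with a stated time of 1 h (a lower number here means a stronger inhibitor, a higher number a weaker inhibitor), compound 1 gives 810 nM. Among the measured compounds shown here, this is the only plain number in the set; the one other measurement is a limit rather than a number. That limit belongs to compound 2, with the structure `Cc1[nH]n(-c2nc3ccccc3[nH]2)c(=O)c1Cc1ccc(Cl)cc1Cl`, which in this assay reaches the limit of > 10000 nM. For the measured compounds named here, compound 2 is the single value sitting at the limit of > 10000 nM in this assay, at which 1 of the 2 values shown sits, and it differs from compound 1 in more than one place, so the pair gives no single measured step. Compound 3, with the structure `Cc1[nH]n(-c2nc3cc(C(C)(C)C)ccc3[nH]2)c(=O)c1Cc1ccccc1`, has not yet been measured. It differs from compound 1 in one place: tert-butyl in place of phenyl on an aromatic carbon. No step of this kind has been measured among the compounds shown, so the size and direction of the change in this assay rest on expectation alone. A modest shift toward weaker inhibition is expected, with the step from compound 1 to compound 3 estimated as a 2.0-fold higher number from compound 1 to compound 3 (0.30 log units; within the scatter). Compound 3 is accordingly estimated at 1600 nM in this assay, within a range from 500 nM to 5000 nM.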

Compound 3, half-maximal inhibitory concentration: 640 nM
Estimate against measurement, compound 3: 2.5-fold (0.40 log units) above, and the stated range covers the measured number.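

In this assay, putting tert-butyl in place of phenyl on this aromatic carbon gives a 1.3-fold lower number from compound 1 to compound 3 (0.10 log units; within the scatter), a step within the usual scatter, so compound 1 and compound 3 cannot be told apart in this measurement. Among the compounds shown here, this is the first single-change comparison in the set, and it shows that, at this position, the six-membered aromatic ring of phenyl can be exchanged for a group with no ring and 4 heavy atoms, all carbon, with no change beyond the scatter in this assay. Nothing measured among the compounds shown explains why these two groups give results so close together.

As far as these compounds go, both groups that have been compared here contain only carbon and have no hydrogen-bond donors or acceptors, so it remains open whether an amine, a carboxylic acid or a methoxy group on the same carbon would keep a result like that of compound 1. Also open, from the compounds shown here alone, is how far the size of the group matters, which a single methyl or a longer chain at this position could begin to show.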